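The compounds below may be only part of what the source reports. "The series", "measured", "known", "first", "only" and "open" are said of these compounds alone.

Of the compounds shown here, three from this series have been measured in an assay on HEK293 cells for positive allosteric modulation of metabotropic glutamate receptor 2 (Rattus norvegicus), read by thallium flux, with a stated time of 2.5 min; on this read-out higher numbers stand for larger maximal responses and lower numbers for smaller maximal responses. Compound 1 `Cc1c(OCCCCOc2ccc(C(=O)CC(C)(C)C)c(O)c2C)cccc1C(=O)O` gives 95.8% in this assay. Compound 2 `Cc1c(OCCCCOc2ccc(F)c(C(=O)O)c2)ccc(C(=O)CC2CCCC2)c1O` gives 81%, and compound 3 `Cc1c(OCCCCOc2cccc(C(=O)O)c2)ccc(C(=O)CC(C)C)c1O` gives 84.5%. Compound 1 thus stands highest of the three: its nearest neighbour is compound 3, whose number lies beyond the scatter below it, and compound 2 lies further below still. Compound 1 reaches a maximal response close to that of the reference.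

Compound 4 `CC(=O)c1ccc(OCCCCOc2cccc(C(=O)O)c2C)c(C)c1O` has not yet been measured in this assay. It differs from compound 1 in one place: hydrogen in place of tert-butyl on a saturated chain carbon bound to a carbonyl carbon. Put another way, the neopentylcarbonyl group of compound 1 becomes an acetyl group in compound 4. No pair of measured compounds differs by this change alone, so the size of the step cannot be read from the numbers shown. Compounds 2 and 3 both sit below compound 1, but each also differs from it elsewhere, so they say nothing direct about the loss of tert-butyl. The expected step, a number 10.8 percentage points lower from compound 1 to compound 4 (beyond the scatter), is modest and toward a lower maximal response, and may not reach beyond the scatter. Compound 4 is therefore estimated to give 85% in this assay, within a range from 65% to 102%.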

Compound 4, largest response reached (reported as percent of maximum), in percent of the reference or control that the assay uses: 79.2%
Compound 4: the middle estimate sits 5.8 percentage points above what was measured; low and high end bracket the measured number.
By their numbers in this assay, from the lowest: compounds 4, 2 and 3 (each within the scatter of the next); then compound 1.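

Removing the tert-butyl from the saturated chain carbon bound to the carbonyl carbon has a real effect in this assay, with the step being a number 16.6 percentage points lower from compound 1 to compound 4 (beyond the scatter) and lying beyond the usual scatter, so this place on the molecule has a measurable bearing on the maximal response. The step is modest, though, and with only an acetyl group left at this end, compound 4 still gives 79.2%, so the full neopentylcarbonyl group is not needed for a substantial response. Nothing measured here explains why the response falls with this change, and no supporting data on its cause are available.

This single pair leaves open how the response changes between the two extremes, for instance with an ethyl group or a longer straight chain in place of the tert-butyl, and whether a different kind of group at this place, such as a phenyl ring or an amine, could match compound 1. It also leaves open whether the same change would produce a step of similar size on a core carrying the other differences seen in compound 2 or compound 3.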